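The source may hold more compounds than are shown below. What is called first, only, known or untested is meant among the compounds shown, and "the series" means these compounds.

Measured compounds in a functional assay on HL-60 cells (Homo sapiens) for inhibition, read by MTT assay, with a stated time of 48 h; on this read-out lower numbers stand for stronger inhibition and higher numbers for weaker inhibition:
- compound 1, `O=C(/C=C/c1ccccc1Br)c1ccc[nH]1`, gives 42000 nM
- compound 2, `O=C(/C=C/c1ccc(Cl)cc1)c1ccc[nH]1`, gives 13000 nM
- compound 3, `O=C(/C=C/c1cc([N+](=O)[O-])ccc1Cl)c1ccc[nH]1`, gives 38000 nM

Compound 3 holds the second highest of the three numbers in this assay. Its nearest neighbour is compound 1, whose number is higher by a margin within the scatter, so no order can be read between these two. Compound 2 stands furthest away, with a lower number beyond the scatter, and so inhibits more strongly than compound 3.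

Compound 4, `O=C(/C=C/c1cc([N+](=O)[O-])ccc1Cl)c1ccco1`, has not yet been measured. The change from compound 3 is furan-2-yl in place of 1H-pyrrol-2-yl on a carbonyl carbon. Among the measured compounds shown here, no pair of measured compounds shows this swap of one five-membered aromatic ring for another, so the size of the step can only be guessed. The expected step of a 1.2-fold higher number from compound 3 to compound 4 (0.07 log units; within the scatter) is a small weakening, and it may well stay within the scatter. Compound 4 is therefore expected to give about 45000 nM in this assay, with a range from 15000 nM to 130000 nM.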

Compound 4, half-maximal inhibitory concentration: 58000 nM
Beside the measured number, compound 4's estimate is 1.3-fold (0.11 log units) below it; the measured number falls inside the stated range.
By their numbers in this assay, from the lowest: compound 2; then compounds 3, 1 and 4 (each within the scatter of the next).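

Read in this assay, the exchange of 1H-pyrrol-2-yl for furan-2-yl on a carbonyl carbon gives a 1.5-fold higher number from compound 3 to compound 4 (0.18 log units; within the scatter). Among the compounds shown here, the earlier compounds all carried 1H-pyrrol-2-yl at this place, so this is the first view of another ring there, and replacing a ring with a hydrogen-bond donor by one with a hydrogen-bond acceptor leaves no readable difference between compound 3 and compound 4. Nothing at hand explains this result.

The compounds shown leave open whether thiophen-2-yl, or a group carrying an amine or a carboxylic acid, would move the number beyond the scatter at this carbonyl carbon. They also leave open whether furan-2-yl would read the same on the other end of compound 2, which gives 13000 nM.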